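The source may report more compounds than this note shows. Statements on the series, on what has been measured and on what is new or still open speak of the compounds shown alone.

In a physicochemical assay for lipophilicity, at pH 7.4 (a lower number here means a more polar compound, a higher number a more lipophilic compound), compound 3 `O=S(=O)(O)Nc1ccc(-c2nc3ccccc3s2)cc1` reads 7.5, the higher of the two actual numbers available. The other number belongs to compound 1 `Cc1cc(-c2nc3ccccc3s2)ccc1N` at 2.51, far lower and well beyond the scatter. Compound 2 `Nc1ccc(-c2nc3ccccc3s2)cc1I` gives > 2.7, which is a limit and not a number.

Compound 4 `Cc1cc(-c2nc3ccccc3s2)ccc1NS(=O)(=O)O` differs from compound 3 by a single change, (methyl in place of hydrogen on an aromatic carbon), with methyl in place of hydrogen on an aromatic carbon, ortho to a sulfoamino group.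

Within the data shown here, no measured step makes this exact swap. The nearest is a number at least 0.19 log units higher from compound 1 to compound 2 (that floor lies within the scatter), where iodo takes the place of methyl on an aromatic carbon. Among the measured compounds shown here, that step is open-ended, resting on (the limit of > 2.7 in this assay, at which 1 of the 3 values shown sits), and it is the only guide here, so it offers weak support for anything more than a small change. The expected move is a number 0.10 log units higher from compound 3 to compound 4 (within the scatter), a slight rise that would not clear the scatter. Compound 4 is therefore estimated at 7.6, with an expected range from 6.9 to 8.3.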

Compound 4, distribution coefficient: < 3
Compound 4 gave a limit, no number; the forecaster's own chance of this, stated with the estimate: 5%; at least 4.60 log units between middle value and limit.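

Compound 4 gives < 3 in this assay, which is a limit and not a number. Even so, methyl in place of hydrogen on an aromatic carbon, ortho to a sulfoamino group, comes with a number at least 4.50 log units lower from compound 3 to compound 4 (beyond the scatter). Among these compounds, a single methyl at this position can therefore go with a large step, which the one earlier step, iodo in place of methyl, did not show, since its floor lies within the scatter.

As far as these compounds go, the step from compound 1 to compound 4 cannot be read, and the full size of the fall from compound 3 stays open: the limit of < 3 in this assay, at which 1 of the 4 values shown sits. The compounds shown also leave open what an ethyl chain or a methoxy group would do at this same position, and whether a carboxylic acid in place of the sulfoamino group would go with a similar step.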